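This account rests on a few compounds, and the source may have more. Where it says the series, first, only, none or still open, it means among the compounds named here.

Measured so far:
compound 1 `Cn1c(-c2ccc(NC(=O)CSc3nc4ccccc4o3)cc2)nc(-c2ccccc2)c1-c1ccccc1`: 76.3%
compound 2 `Cc1nnc(SCC(=O)Nc2ccc(-c3nc(-c4ccccc4)c(-c4ccccc4)n3C)cc2)s1`: 85.2%
compound 3 `CCN1CCN(CC(=O)Nc2ccc(-c3nc(-c4ccccc4)c(-c4ccccc4)n3C)cc2)CC1`: 46.3%

In a functional assay on MCF7 cells (Homo sapiens) for cytotoxicity, read by MTT assay, with a stated time of 24 h, tested at 80 ug/mL (a higher number here means a stronger effect of the compound at the concentration tested, a lower number a weaker effect), compound 3 stands lowest of the three numbers: a number 30 percentage points lower from compound 1 to compound 3 (beyond the scatter) and a number 38.9 percentage points lower from compound 2 to compound 3 (beyond the scatter). Compound 4 `Cc1ccc(CN2CCN(CC(=O)Nc3ccc(-c4nc(-c5ccccc5)c(-c5ccccc5)n4C)cc3)CC2)cc1` differs from compound 3 at a single place: 4-methylphenyl in place of methyl on a saturated chain carbon bound to an amine nitrogen in a ring. Among the measured compounds shown here, no measured step touches this part of the molecule; the two steps that reach compound 3 both exchange the whole group on the carbon bound to the carbonyl, so they set only the starting level, not the direction of this change. He therefore expects no step beyond the scatter, and estimates a number 5.7 percentage points higher from compound 3 to compound 4 (within the scatter). For compound 4 the estimate in this assay is 52%, within a range of 38% to 68%.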

Compound 4, a percentage reported as activity, at one concentration (the size of the read-out at that concentration, not a potency): 49.3%
The estimate for compound 4 lay 2.7 percentage points above the measured number, within the range that was stated.
By their numbers in this assay, from the lowest: compounds 3 and 4 (each within the scatter of the next); then compounds 1 and 2 (each within the scatter of the next).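

Exchanging methyl for 4-methylphenyl on a saturated chain carbon bound to an amine nitrogen in a ring gives, in this assay, a number 3 percentage points higher from compound 3 to compound 4 (within the scatter). Among the compounds shown here, this place therefore accepts an added six-membered aromatic ring of carbon only without a step beyond the scatter, which the earlier steps, all made on the carbon bound to the carbonyl, could not show. No available evidence bears on this result. Going by these compounds, whether a carboxylic acid, a primary amine or a longer chain at this place would give a larger step remains open.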